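Pyridinylmethyl in place of branched alkyl on the ring nitrogen

A few compounds are considered here, and "the series" means these few. Any claim that something is new, unique, unknown or untested is made for them only; others in the source may bear on it.

Two compounds of this core have been run in an in vitro ADME assay on microsomes from liver (Homo sapiens) for metabolic stability, tested at 5 uM; a higher number here means that the compound lasts longer, a lower number that the compound disappears faster. Compound 1 `COCN(c1ccc2c(c1)S(=O)(=O)N=C(c1c(O)c(-c3cccs3)nn(CCC(C)C)c1=O)N2)S(C)(=O)=O` gives 0.183 h. Compound 2 `CCC(C)CCn1nc(-c2cccs2)c(O)c(C2=NS(=O)(=O)c3cc(NS(C)(=O)=O)ccc3N2)c1=O` reaches only a limit of the assay in this assay, reported as > 1 h; the reading is a limit, not a number, and compound 2 therefore stands at the limit on the evidence shown (the limit of > 1 h in this assay, at which 1 of the 2 values shown sits). Among the compounds with values here, compound 1 and compound 2 differ in more than one place, so no single step connects them; the two values show only that one sits well below the limit and the other at it.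

Compound 3 `CS(=O)(=O)Nc1ccc2c(c1)S(=O)(=O)N=C(c1c(O)c(-c3cccs3)nn(Cc3ccccn3)c1=O)N2` is unmeasured. It differs from compound 2 by pyridin-2-yl in place of 2-methylbutyl on a saturated chain carbon bound to an aromatic nitrogen.

Within the data shown here, no measured step informs this change. A step of modest size, if any, is expected from compound 2 to compound 3, a number no higher from compound 2 to compound 3 (the limit leaves the size open), with no clear direction beyond the scatter. Compound 3 is estimated at 1 h, in the range 0.35 h to 2.5 h.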

Compound 3, half-life: > 1 h
Compound 3 gave a limit, no number (the forecaster's own chance of this, stated with the estimate: 45%); the middle value lies on the limit itself.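

Compound 2 and compound 3 both stand at a limit of this assay, not at a number, so no step between them can be read: the limit of > 1 h in this assay, at which 2 of the 3 values shown sit.

Open remains how far either compound lies past that limit, and whether pyridin-2-yl in place of 2-methylbutyl shifts the half-life at all.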